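Swapping Chloro for Fluoro on a Weakly Toxic Core

The source may hold more compounds than are shown below. What is called first, only, known or untested is meant among the compounds shown, and "the series" means these compounds.

Compound 3 `Cc1ccc([C@@H]2C[C@H](O)Cc3cc(Cl)ccc3N2)o1` carries a chloro on its shared core. In an ADME assay on THP-1 cells (Homo sapiens) for cytotoxicity (on this read-out higher numbers stand for lower toxicity in this test and lower numbers for higher toxicity in this test), compound 3 gives only a limit of the assay, > 1080000 nM. For the measured compounds named here, compound 3 is the one value that sits at the limit of > 1080000 nM in this assay, at which 1 of the 3 values shown sits. Two relatives give numbers instead: compound 1 `O[C@@H]1Cc2cc(F)ccc2N[C@H](c2cccs2)C1` gives 190000 nM in this assay, and compound 2 `Cc1ccsc1[C@@H]1C[C@H](O)Cc2cc(F)ccc2N1` gives 1810000 nM. Going by the values given here, the only step between measured compounds, a 9.5-fold higher number from compound 1 to compound 2 (0.98 log units; beyond the scatter), concerns a methyl on an aromatic carbon and says nothing about a halogen.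

Compound 4 `Cc1ccc([C@@H]2C[C@H](O)Cc3cc(F)ccc3N2)o1` is the compound still to be measured. The change from compound 3 to compound 4 is fluoro in place of chloro on an aromatic carbon. Among the compounds with values here, no measured step compares a chloro with a fluoro, so there is no direct guide to the size of this step in this assay, and compound 3 itself offers only a limit rather than a number. Compound 2, which also carries a fluoro, gives 1810000 nM in this assay. The step expected in this assay is a step that the limit leaves unreadable from compound 3 to compound 4, that is, nothing beyond the scatter. Compound 4 is therefore estimated at 1200000 nM, with a range from 400000 nM to 4000000 nM, and a limit rather than a number is quite likely.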

Compound 4, half-maximal cytotoxic concentration: > 1140000 nM
Compound 4 was reported as a limit (the forecaster's own chance of this, stated with the estimate: 60%); the middle value lies beyond the limit too.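

In this assay, compound 4, with fluoro on this aromatic carbon, ends at a limit rather than a number: the limit of > 1140000 nM in this assay, at which 1 of the 4 values shown sits. Compound 3, its chloro partner, is also a limit: the limit of > 1080000 nM in this assay, at which 1 of the 4 values shown sits. The steps from compound 3 and from compound 2 to compound 4 cannot be read, so neither halogen at this position has yet been tied to a measured toxicity, but the change to 5-methylfuran-2-yl from thiophen-2-yl on a saturated ring carbon can be read, and with the fluoro held constant it gives an at least 6.0-fold higher number from compound 1 to compound 4 (0.77 log units; beyond the scatter), which places compound 4 on the less toxic side of compound 1.

As far as these compounds go, whether fluoro and chloro differ at all in this test stays open, as does the true distance between compound 4 and compound 2, with no number for compound 3 or compound 4 to work from. An amine or a carboxylic acid on this same aromatic carbon would show whether a group very unlike a halogen brings the read-out down from the limit and gives a number that can be compared.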